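Methoxy to Nitro on the Sulfonyl Aryl Ring

The source may hold more compounds than are shown below. What is called first, only, known or untested is meant among the compounds shown, and "the series" means these compounds.

Measured compounds:
Compound 1 `Nc1nc2c(c(=O)n(CC3CC3)c(=O)n2CC2CC2)n1S(=O)(=O)c1ccc(C(F)(F)F)cc1`: 0%
Compound 2 `COc1ccc(S(=O)(=O)n2c(N)nc3c2c(=O)n(CC2CC2)c(=O)n3CC2CC2)cc1`: 25%

In an assay on isolated protein with dual specificity calcium/calmodulin-dependent 3',5'-cyclic nucleotide phosphodiesterase 1B (Bos taurus) as the target, tested at 100 uM (a lower number here means less inhibition, a higher number more inhibition at the concentration tested (going by the name of the read-out)), compound 2 gives 25%, the higher of the two numbers; compound 1 gives 0%. Within the data shown here, the only measured step, a number 25 percentage points higher from compound 1 to compound 2 (beyond the scatter), shows that exchanging the group on this aromatic carbon can move the reading modestly. Compound 3 `Nc1nc2c(c(=O)n(CC3CC3)c(=O)n2CC2CC2)n1S(=O)(=O)c1ccc([N+](=O)[O-])cc1` differs from compound 2 by nitro in place of methoxy on an aromatic carbon. Among the measured compounds shown here, no measured compound carries a nitro group, so that step gives only indirect guidance: one exchange at this carbon produced a modest gain, and a second exchange may equally well take part of it back. The expected step of a number 13 percentage points lower from compound 2 to compound 3 (beyond the scatter) is therefore a small drop, possibly within the scatter. Compound 3 is estimated at 12%, within a range from 0% to 35%.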

Compound 3, a percentage reported as inhibition, at one concentration (the size of the read-out at that concentration, not a potency): 14%
Compound 3: middle estimate off by 2 percentage points, on the low side; the range from low to high includes it.
By their numbers in this assay, from the lowest: compound 1; then compound 3; then compound 2.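

Replacing methoxy with nitro gives a number 11 percentage points lower from compound 2 to compound 3 (beyond the scatter) in this assay, while replacing trifluoromethyl with nitro gives a number 14 percentage points higher from compound 1 to compound 3 (beyond the scatter) in the same test. The three groups on this aromatic carbon therefore give three separate readings, with nitro falling between the other two, so the earlier contrast between two groups was not simply all or nothing. No supporting measurement is available to explain why the groups fall in this order.

The compounds shown leave open how an amine or a carboxylic acid on this carbon would read, and whether a plain hydrogen there would give a lower or higher number than these three groups. They also leave open whether the same order would hold with changes elsewhere on the shared core.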